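Swapping One Side Chain on a Weakly Cytotoxic Compound

The source may report more compounds than this note shows. Statements on the series, on what has been measured and on what is new or still open speak of the compounds shown alone.

Within the data shown here, only two compounds have been measured so far in a functional assay on HeLa cells (Homo sapiens) for cytotoxicity, read by MTT assay; a higher number here means a weaker inhibitor, a lower number a stronger inhibitor. Compound 1 (`CC(C)=CC[C@@H](OC(=O)CCO)C1=CC(=O)c2c(O)ccc(O)c2C1=O`) gives 67600 nM. Compound 2 (`CCCCC(CC(=O)O[C@H](CC=C(C)C)C1=CC(=O)c2c(O)ccc(O)c2C1=O)OC(C)=O`) gives 73500 nM. Compound 2 therefore stands level with compound 1, since the two numbers lie within the scatter of repeated measurements.

Compound 3 (`CCCCCCC(C)(O)CC(=O)O[C@H](CC=C(C)C)C1=CC(=O)c2c(O)ccc(O)c2C1=O`) keeps the shared core and changes one group: 1-hydroxy-1-methylheptyl in place of 1-acetoxypentyl on a saturated chain carbon bound to a carbonyl carbon. In plain words, 1-hydroxy-1-methylheptyl takes the place of 1-acetoxypentyl on a saturated chain carbon bound to a carbonyl carbon.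

Among the measured compounds shown here, one measured step bears on this change, as it altered the group at the same place, putting 1-acetoxypentyl in place of hydroxymethyl. That step was a 1.1-fold higher number from compound 1 to compound 2 (0.04 log units; within the scatter). Given this result, no step beyond the scatter is expected in this assay, and no direction can be favoured, although a single step is thin evidence. The expected step is a 1.1-fold lower number from compound 2 to compound 3 (0.02 log units; within the scatter). The estimated value for compound 3 is 70000 nM, with an expected range from 33000 nM to 130000 nM.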

Compound 3, half-maximal inhibitory concentration: > 100000 nM
Compound 3 ended at the assay's limit (the forecaster's own chance of this, stated with the estimate: 8%); middle value at least 1.4-fold (0.15 log units) from the limit.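

In this assay compound 3 gives > 100000 nM, which is a limit of the assay and not a number: the limit of > 100000 nM in this assay, at which 1 of the 3 values shown sits.

Set against the earlier compounds, this gives an at least 1.3-fold higher number from compound 2 to compound 3 (0.13 log units; that floor lies within the scatter) and an at least 1.4-fold higher number from compound 1 to compound 3 (0.17 log units; that floor lies within the scatter). Unlike the first change at this place, the swap to 1-hydroxy-1-methylheptyl leaves the true size of its step unknown, as only a floor can be read, so compound 3 may sit level with the other two compounds or well beyond them. What it adds is that a third group on a saturated chain carbon bound to a carbonyl carbon also gives no sign of a stronger inhibitor, so none of the groups at this place has yet lowered the number.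

The swap from 1-acetoxypentyl to 1-hydroxy-1-methylheptyl alters the chain and the oxygen-bearing group together, so these compounds cannot separate the effect of one from the other. On these data alone, how an amine or a carboxylic acid at this same place would read in this assay remains open.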